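A few compounds are considered here, and "the series" means these few. Any claim that something is new, unique, unknown or untested is made for them only; others in the source may bear on it.

Measured compounds: compound 1 `O[C@@H](c1ccccc1)[C@H]1CO[C@H](c2ccccc2)[C@@H](C/C=C/c2ccccn2)C1`, compound 2 `O[C@@H](c1ccccc1)[C@H]1CO[C@H](c2ccccc2)[C@@H](C/C=C/c2ccncc2)C1`, compound 3 `O[C@@H](c1ccccc1)[C@H]1CO[C@H](c2ccccc2)[C@@H](C/C=C/C2CCCCC2)C1`.

In a functional assay on HL-60 cells (Homo sapiens) for cytotoxicity, read by WST assay, with a stated time of 48 h (on this read-out higher numbers stand for weaker inhibition and lower numbers for stronger inhibition), compound 1 gives 36400 nM. Compound 2 gives no number but a limit of the assay, > 100000 nM (the limit of > 100000 nM in this assay, at which 1 of the 3 values shown sits). Compound 3 gives 6260 nM, the lowest of the two numbers shown, and the nearest number, that of compound 1, sits well beyond the scatter from it. Compound 4 `COc1cccc(/C=C/C[C@H]2C[C@@H]([C@@H](O)c3ccccc3)CO[C@@H]2c2ccccc2)c1` has not yet been measured; it differs from compound 3 in that (3-methoxyphenyl in place of cyclohexyl on a double-bonded chain carbon bound to a double-bonded chain carbon). For the measured compounds named here, two measured steps bear on this change: a 5.8-fold lower number from compound 1 to compound 3 (0.76 log units; beyond the scatter) and an at least 15-fold lower number from compound 2 to compound 3 (1.20 log units; beyond the scatter), both going from an aromatic ring to cyclohexyl with lower numbers. Reversing that direction, compound 4 is expected to show a modest rise, a 2.2-fold higher number from compound 3 to compound 4 (0.35 log units; beyond the scatter). For compound 4 the estimate is 14000 nM, with a range from 4500 nM to 45000 nM.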

Compound 4, half-maximal inhibitory concentration: 9620 nM
Compound 4: middle estimate off by 1.5-fold (0.16 log units), on the high side; the measured number falls inside the stated range.
By their numbers in this assay, from the lowest: compounds 3 and 4 (each within the scatter of the next); then compound 1. At a limit, above all of these: compound 2.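

In this assay, the 3-methoxyphenyl ring at this place gives a 1.5-fold higher number from compound 3 to compound 4 (0.19 log units; within the scatter) and, set against a pyridine ring, a 3.8-fold lower number from compound 1 to compound 4 (0.58 log units; beyond the scatter) in this series. The earlier contrast between cyclohexyl and an aromatic ring therefore holds for pyridin-2-yl and pyridin-4-yl, but compound 4 goes against it. Compound 2 gives only a limit of the assay, so an at least 10-fold lower number from compound 2 to compound 4 (1.01 log units; beyond the scatter) rests on that limit: the limit of > 100000 nM in this assay, at which 1 of the 4 values shown sits.

The compounds shown leave open what plain phenyl, without the methoxy group, would give at this place. From the compounds shown here alone, an amine on the ring and a longer chain also remain open.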